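This account rests on a few compounds, and the source may have more. Where it says the series, first, only, none or still open, it means among the compounds named here.

Measured compounds and their values:

- compound 1, `C=CC1=C(C(=O)NCc2ccc(C)cc2)C(c2ccc(F)cc2)OC1` — 62100 nM
- compound 2, `C=CC1=C(C(=O)NCCCCC)C(c2ccc(Cl)c(Cl)c2)OC1` — > 100000 nM
- compound 3, `C=CC1=C(C(=O)NC(C)(C)C)C(c2ccc(OC)cc2)OC1` — > 100000 nM

All three share a core and were tested in a functional assay on QGY7701 cells (Homo sapiens) for cytotoxicity, read by MTT assay, with a stated time of 24 h; on this read-out higher numbers stand for weaker inhibition and lower numbers for stronger inhibition. Compound 1 is the only one of the three for which an actual number is reported, and that number sits in a weak range. For compound 2 the result is a limit of the assay rather than a number. For compound 3 the result is likewise a limit of the assay. So compound 1 stands alone as the only measured value, while the limit of > 100000 nM in this assay, at which 2 of the 3 values shown sit, describes where the other two sit.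

Compound 4, `C=CC1=C(C(=O)NCC(C)C)C(c2ccc(F)cc2)OC1`, differs from compound 1 in one place: isopropyl in place of 4-methylphenyl on a saturated chain carbon bound to an amide-type nitrogen. Going by the values given here, no step between two measured compounds shows what this kind of change does here; the only other measured compounds, compound 2 and compound 3, carry different amide substituents and different aryl groups and reach only the limit. Across the step from compound 1 to compound 4 a small move toward weaker inhibition, or no change beyond the scatter, is expected, a 1.4-fold higher number from compound 1 to compound 4 (0.16 log units; within the scatter). Compound 4 is therefore expected to give about 90000 nM, within 40000 nM to 200000 nM, with a fair chance that only a limit is reported.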

Compound 4, half-maximal inhibitory concentration: > 100000 nM
Compound 4: only a limit was reported (the forecaster's own chance of this, stated with the estimate: 45%); middle value at least 1.1-fold (0.04 log units) from the limit.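

Going by these compounds alone, this is the first pair here that differs in one place only, so it gives the first direct reading of this position: with the rest of the molecule unchanged, isopropyl in place of 4-methylphenyl on a saturated chain carbon bound to an amide-type nitrogen gives an at least 1.6-fold higher number from compound 1 to compound 4 (0.20 log units; that floor lies within the scatter) in this assay. The result for compound 4 is a limit of the assay and not a number, so this step is only a floor: the real gap could be small or much larger, and it cannot be said to lie beyond the scatter. Even so, with this one change compound 4 no longer gives a measurable number and joins compound 2 and compound 3: the limit of > 100000 nM in this assay, at which 3 of the 4 values shown sit.

The change removes the aromatic ring and also lowers the heavy-atom count, and this single pair cannot tell which of the two matters. From the compounds shown here alone, how a cyclohexyl group, which keeps a ring without being aromatic, or a longer chain ending in an amine would read at this place remains open.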